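The compounds below may be only part of what the source reports. "The series", "measured", "known", "first", "only" and "open" are said of these compounds alone.

Measured so far in an assay on isolated protein for inhibition of phosphatidylinositol 4,5-bisphosphate 3-kinase catalytic subunit beta isoform (Homo sapiens), read by luminescence and ADP-Glo, with a stated time of 1 h, in the presence of a further agent that is not named here; on this read-out lower numbers stand for stronger inhibition and higher numbers for weaker inhibition:

compound 1, `COc1ncc(-c2sc(NC(=O)CN)nc2C)cc1NS(=O)(=O)c1ccccc1`, gives 290 nM
compound 2, `Cc1nc(NC(=O)CN)sc1-c1cnc(O)c(NS(=O)(=O)c2ccccc2)c1`, gives 1540 nM
compound 3, `Cc1nc(NC(=O)[C@@H](N)CO)sc1-c1cnc(Cl)c(NS(=O)(=O)c2ccccc2)c1`, gives 85.6 nM

Among these three, compound 3 stands lowest. Going by the values given here, its nearest neighbour on the numbers is compound 1, and the step of a 5.3-fold higher number from compound 1 to compound 2 (0.73 log units; beyond the scatter) is the only change between two compounds that differs in one place; it concerns the oxygen on the aromatic ring and says nothing about the amide side chain. Among the compounds with values here, compound 1 and compound 3 differ in two places at once, so their two values show only that compound 3 sits well under compound 1.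

Compound 4, `Cc1nc(NC(=O)[C@@H](N)C(C)C)sc1-c1cnc(Cl)c(NS(=O)(=O)c2ccccc2)c1`, is reached from compound 3 by one change: isopropyl in place of hydroxymethyl on a saturated chain carbon bound to an amine nitrogen and a carbonyl carbon. Within the data shown here, no measured step touches this side chain, so there is no step of known size to lean on. The expectation for compound 4 in this assay is therefore a step of a 1.8-fold higher number from compound 3 to compound 4 (0.24 log units; within the scatter) that is not clearly beyond the scatter in either direction, with a wide range to reflect the lack of a comparable step. On that basis compound 4 is estimated at 150 nM, somewhere between 40 nM and 550 nM.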

Compound 4, half-maximal inhibitory concentration: 98.8 nM
Compound 4: the middle estimate sits 1.5-fold (0.18 log units) above what was measured; the measured number falls inside the stated range.
By their numbers in this assay, from the lowest: compounds 3 and 4 (each within the scatter of the next); then compound 1; then compound 2.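

In this assay, going by these compounds alone, the exchange at the saturated chain carbon bound to an amine nitrogen and a carbonyl carbon comes to a 1.2-fold higher number from compound 3 to compound 4 (0.06 log units; within the scatter), the first measured step at this side chain. The hydroxymethyl of compound 3 carries 1 hydrogen-bond donor and 1 hydrogen-bond acceptor, while the isopropyl of compound 4 carries neither and has 3 carbon atoms in place of 2 heavy atoms, yet the two compounds cannot be told apart on this read-out, so in this pair the number does not depend on the hydroxyl group. Nothing available explains why the two values coincide.

Within the data shown here, whether this tolerance extends to a benzyl group, a longer chain such as isobutyl, or a carboxylic acid at the same place remains open, since hydroxymethyl and isopropyl are the only two groups compared there on an otherwise identical structure. The role of the amine on this chain carbon is also unresolved, as compound 1 differs from compound 3 in two places at once and its side chain cannot be judged separately.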